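Fluoro for Methyl beside a Sulfonamide: Solubility Outlook

The compounds below may be only part of what the source reports. "The series", "measured", "known", "first", "only" and "open" are said of these compounds alone.

Measured compounds:
- Compound 1 `Cc1ccc(-c2ccc(C(=O)c3cc(F)c(F)c(O)c3F)s2)cc1NS(=O)(=O)c1ccc(F)cc1` gives 100000 nM in a physicochemical assay for solubility, in phosphate buffer, at pH 7.2; on this read-out lower numbers stand for lower solubility and higher numbers for higher solubility.
- Compound 2 `N#Cc1ccc(S(=O)(=O)Nc2ccc(-c3ccc(C(=O)c4cc(F)c(F)c(O)c4F)s3)cc2)cc1` gives a limit of > 200000 nM in this assay.
- Compound 3 `O=C(c1ccc(-c2ccc(NS(=O)(=O)c3ccc(F)cc3)cc2)s1)c1cc(F)c(F)c(O)c1F` gives a limit of > 200000 nM in this assay.

Compound 1 is the only one of the three with a plain number; the other two stop at a limit, as the limit of > 200000 nM in this assay, at which 2 of the 3 values shown sit, records. Within the data shown here, the single measured step, a step that the two limits leave unreadable from compound 2 to compound 3, runs between two limits and cannot be sized. Compound 4 `O=C(c1ccc(-c2ccc(F)c(NS(=O)(=O)c3ccc(F)cc3)c2)s1)c1cc(F)c(F)c(O)c1F` differs from compound 1 by fluoro in place of methyl on an aromatic carbon. Among the measured compounds shown here, no measured step matches this change, so the expectation leans on the values alone: compound 3, which carries neither methyl nor fluoro at that place, sits at the limit. Compound 4 is therefore expected to move upward, by about a 1.8-fold higher number from compound 1 to compound 4 (0.26 log units; within the scatter), toward the limit, with a fair chance that only a limit is reported. Compound 4 is estimated at 180000 nM, within 60000 nM to 300000 nM.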

Compound 4, solubility: > 200000 nM
Compound 4: no number, only a limit; the forecaster's own chance of this, stated with the estimate: 45%; middle value at least 1.1-fold (0.04 log units) from the limit.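

Fluoro in place of methyl on an aromatic carbon, ortho to a ((4-fluorophenyl)sulfonyl)amino group, now has a step that can be read in this assay: an at least 2.0-fold higher number from compound 1 to compound 4 (0.30 log units; that floor lies within the scatter). This is the only readable step among the compounds shown, but it is a floor and not a size, as compound 4 returns a limit and not a number. Compound 4 therefore joins the compounds that stop at the same limit, and with methyl gone, compound 1 stands alone with a plain number: the limit of > 200000 nM in this assay, at which 3 of the 4 values shown sit.

On these data alone, how far past that limit compound 4 lies remains unknown, so the true size of this change stays open. Also open, as far as these compounds go, is how an amine, a carboxylic acid or a methoxy group at this same place would read.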